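Thiosemicarbazide series: ring swap on the thiocarbonyl carbon

The compounds below may be only part of what the source reports. "The series", "measured", "known", "first", "only" and "open" are said of these compounds alone.

Three measured compounds share one core and differ only in the ring carried on the thiocarbonyl carbon. Compound 1 `Cc1ccnc(/C(N)=N/NC(=S)N2CCCC2)c1` is the reference; in a functional assay on A-431 cells (Homo sapiens) for cytotoxicity, read by MTT assay, with a stated time of 72 h, tested at 100 uM (a lower number here means less inhibition of growth, a higher number more inhibition of growth at the concentration tested), compound 1 gives 86.9%. Compound 2 `Cc1cccc(/C(N)=N/NC(=S)N2CCCC2)n1` gives 86.8% in this assay, and compound 3 `N/C(=N\NC(=S)N1CCCCCC1)c1ccccn1` gives 77.5%. Compound 1 thus holds the highest of the three numbers, but both compound 2 and compound 3 sit within the scatter of it, so no order among the three can be drawn.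

Compound 4 `Cc1ccnc(/C(N)=N/NC(=S)N2CCOCC2)c1` differs from compound 1 by morpholin-4-yl in place of pyrrolidin-1-yl on a thiocarbonyl carbon. Among the measured compounds shown here, no measured pair with this change exists; with a different ring on the thiocarbonyl carbon compound 3 gives 77.5%, while compound 1 gives 86.9%, a gap inside the scatter. A step from compound 1 to compound 4 no larger than the scatter is therefore expected, estimated as a number 8.9 percentage points lower from compound 1 to compound 4 (within the scatter). For compound 4 the expected value in this assay is 78%, with a range from 58% to 92%.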

Compound 4, percent growth inhibition at one concentration: 82.8%
Compound 4: the middle estimate sits 4.8 percentage points below what was measured; measured number inside the range.
By their numbers in this assay, from the lowest: compounds 3, 4, 2 and 1 (each within the scatter of the next).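

Among the compounds shown here, this is the first step with one change on the shared core: in this assay, morpholin-4-yl in place of pyrrolidin-1-yl on the thiocarbonyl carbon gives a number 4.1 percentage points lower from compound 1 to compound 4 (within the scatter). At this position, then, a six-membered ring with a second hetero atom and one hydrogen-bond acceptor is accepted without a step beyond the scatter. Nothing available bears on the reason for this result.

Open, from the compounds shown here alone, is whether a piperazin-1-yl ring or an open-chain dimethylamino group on the same carbon would stay within the scatter. Also open, going by these compounds, is whether this swap behaves alike on the core of compound 2.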